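A few compounds are considered here, and "the series" means these few. Any claim that something is new, unique, unknown or untested is made for them only; others in the source may bear on it.

In an ADME assay on Vero cells (Chlorocebus sabaeus) for cytotoxicity, read by MTT assay, with a stated time of 72 h (a higher number here means that more compound is needed for the effect, a lower number that less compound is needed), compound 1 (`O=C(Nc1nc(-c2ccccn2)cs1)c1ccc(OCc2ccccc2)cc1`) gives 2300 nM as its result. Compound 2 (`COc1cccc(C(=O)Nc2nc(-c3ccccn3)cs2)c1`) gives 2800 nM in the same test, so the two numbers lie within the usual scatter of each other and cannot be ranked. Compound 3 (`O=C(Nc1nc(-c2ccccn2)cs1)c1cccc([N+](=O)[O-])c1`) shares the core of compound 1, but for compound 3 the entry reads "not determined" (no result reported). Among the compounds with values here, compound 1 therefore stands level with the only other number available.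

Compound 4 (`O=C(Nc1nc(-c2ccccn2)cs1)c1ccc(Br)cc1`) has not yet been measured. It differs from compound 1 in one place, with bromo in place of benzyloxy on an aromatic carbon, para to a large group (bromo in place of benzyloxy on an aromatic carbon). Within the data shown here, no measured pair shows what this particular swap does, so any expectation rests on thin evidence. Among the measured compounds shown here, the one guide is that compound 1 at 2300 nM and compound 2 at 2800 nM carry different groups and still give numbers within the scatter. The expected step is a 1.5-fold higher number from compound 1 to compound 4 (0.18 log units; within the scatter) and so stays within the scatter, with a slight lean towards a higher number. In this assay the estimate for compound 4 is 3500 nM (expected range 1200 nM to 12000 nM).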

Compound 4, half-maximal effective concentration: 4700 nM
Compound 4: middle estimate off by 1.3-fold (0.13 log units), on the low side; low and high end bracket the measured number.
By their numbers in this assay, from the lowest: compounds 1, 2 and 4 (each within the scatter of the next, the first and the last beyond it).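

In this assay, within the data shown here, replacing benzyloxy with bromo on an aromatic carbon, para to a large group, gives a 2.0-fold higher number from compound 1 to compound 4 (0.31 log units; beyond the scatter), the first step here that can be read between compounds differing in only one place. It shows that this position is not indifferent to its substituent: when a group of 8 heavy atoms with its own six-membered aromatic ring gives way to a single bromine, more compound is needed for the cytotoxic effect, although the step is modest. No measured property of these groups is available to explain the step.

The change also removes the oxygen and the ring together, so this single pair cannot separate what each contributes, or show whether the bromine itself matters. An ethoxy group, an amine or a carboxylic acid at the same place would help show whether the number follows the size of the group or depends on the kind of atoms it carries, and a plain hydrogen there would give a baseline for both compound 1 and compound 4.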